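Amide-nitrogen substituents on a shared core: compound 4

The source may hold more compounds than are shown below. What is called first, only, known or untested is meant among the compounds shown, and "the series" means these compounds.

Measured so far in an assay on isolated protein for inhibition of histone deacetylase 4 (Homo sapiens), with a stated time of 1 h; on this read-out lower numbers stand for stronger inhibition and higher numbers for weaker inhibition:
compound 1, `Cc1ccc(NC(=O)COc2ccc3cc(/C=C4/SC(=O)NC4=O)ccc3c2)cc1`: 1700 nM
compound 2, `O=C(COc1ccc2cc(/C=C3/SC(=O)NC3=O)ccc2c1)Nc1cc(Cl)cc(C(F)(F)F)c1`: 4000 nM
compound 3, `Cc1cc(NC(=O)COc2ccc3cc(/C=C4/SC(=O)NC4=O)ccc3c2)no1`: 1700 nM

Compound 2 gives the highest number of the three in this assay; its nearest neighbour is compound 1, and the step between them runs the other way, a 2.4-fold higher number from compound 1 to compound 2 (0.37 log units; beyond the scatter), so for the rest only the values are compared: compound 1 sits at 1700 nM, compound 3 at 1700 nM, and the step from compound 1 to compound 3 is no change at the digits printed from compound 1 to compound 3 (within the scatter). The step of a 2.4-fold higher number from compound 1 to compound 2 (0.37 log units; beyond the scatter) and the step of a 2.4-fold lower number from compound 2 to compound 3 (0.37 log units; beyond the scatter) both mark compound 2 as the outlier, and compound 1 and compound 3 cannot be ordered against each other.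

Compound 4, `O=C(COc1ccc2cc(/C=C3/SC(=O)NC3=O)ccc2c1)Nc1ccccn1`, is not yet measured in this assay. Its change from compound 2: pyridin-2-yl in place of 3-chloro-5-(trifluoromethyl)phenyl on an amide-type nitrogen

Going by the values given here, the steps that bear on it are a 2.4-fold lower number from compound 2 to compound 3 (0.37 log units; beyond the scatter) and a 2.4-fold higher number from compound 1 to compound 2 (0.37 log units; beyond the scatter): both times a smaller group in place of, or instead of, the 3-chloro-5-(trifluoromethyl)phenyl on the amide-type nitrogen went with a modestly lower number. The pyridin-2-yl in compound 4 is closer to the 5-methyl-1,2-oxazol-3-yl of compound 3 than to the group it replaces, so a step of similar size and direction is expected, a 2.2-fold lower number from compound 2 to compound 4 (0.35 log units; beyond the scatter).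

Compound 4 is therefore estimated at 1800 nM in this assay, in the range 800 nM to 4000 nM.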

Compound 4, half-maximal inhibitory concentration: 17000 nM
The estimate for compound 4 lay 9.4-fold (0.98 log units) below the measured number, outside the stated range (above it).
By their numbers in this assay, from the lowest: compounds 1 and 3 (each within the scatter of the next); then compound 2; then compound 4.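

In this assay, pyridin-2-yl on the amide-type nitrogen gives a 4.3-fold higher number from compound 2 to compound 4 (0.63 log units; beyond the scatter), so a group with fewer heavy atoms than 3-chloro-5-(trifluoromethyl)phenyl does not by itself go with a lower number, and compound 4 is the weakest of the four. The same group gives a 10-fold higher number from compound 1 to compound 4 (1.00 log units; beyond the scatter) and a 10-fold higher number from compound 3 to compound 4 (1.00 log units; beyond the scatter), the largest steps seen at this position, which shows that the earlier flat read between 4-methylphenyl and 5-methyl-1,2-oxazol-3-yl does not extend to every aromatic ring placed here. A hetero atom in the ring does not sort the series either: compound 3 also carries hetero atoms in its ring on this nitrogen and gives 1700 nM, so it goes against any such rule.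

Nothing measured bears on what separates compound 4 from the other three. Still open, as far as these compounds go, is whether pyridin-3-yl or pyridin-4-yl would read like pyridin-2-yl or return to the values of compound 1 and compound 3, and how a methyl group added to the pyridin-2-yl ring or a benzyl group on this nitrogen would read.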